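Swapping the aryl group on a pyrazole ring nitrogen

This account rests on a few compounds, and the source may have more. Where it says the series, first, only, none or still open, it means among the compounds named here.

Measured so far:
Compound 1, `CN(C)/C=N/c1c(C=O)c(-c2ccccc2)nn1-c1cccc(Cl)c1`: 8300 nM in a functional assay on Jurkat cells (Homo sapiens) for inhibition, read by MTT assay, with a stated time of 72 h; a higher number here means a weaker inhibitor of growth, a lower number a stronger inhibitor of growth
Compound 2, `CN(C)/C=N/c1c(C=O)c(-c2ccccc2)nn1-c1cccc([N+](=O)[O-])c1`: > 50000 nM

For compound 2 the result in this assay is only a limit, > 50000 nM; no number was reached. Among the measured compounds shown here, the one measured step, an at least 6.0-fold higher number from compound 1 to compound 2 (0.77 log units; beyond the scatter), shows that exchanging the aryl substituent on the ring nitrogen changes growth inhibition by at least a modest amount, and that step ends at the limit of > 50000 nM in this assay, at which 1 of the 2 values shown sits.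

Compound 3, `COc1ccc(-n2nc(-c3ccccc3)c(C=O)c2/N=C/N(C)C)cc1`, differs from compound 2 by 4-methoxyphenyl in place of 3-nitrophenyl on an aromatic nitrogen. For the measured compounds named here, no measured step covers a methoxyphenyl here, so the direction of the change is uncertain; the only guide is that compound 1 with chloro gives 8300 nM. For compound 2, by contrast, only a limit was recorded. Compound 3 is therefore expected to fall somewhere between those two, at about 20000 nM, with a range from 5000 nM to 60000 nM. The expected step is then an at least 2.5-fold lower number from compound 2 to compound 3 (0.39 log units; beyond the scatter).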

Compound 3, concentration for 50% growth inhibition: 19700 nM
Compound 3: the middle estimate sits 1.0-fold (0.01 log units) above what was measured, and the stated range covers the measured number.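

Placing 4-methoxyphenyl on the aromatic nitrogen brings growth inhibition back into the range that this assay can measure, giving an at least 2.5-fold lower number from compound 2 to compound 3 (0.40 log units; beyond the scatter). As far as these compounds go, the result for compound 2 is only a limit, so the full size of that step stays unknown: the limit of > 50000 nM in this assay, at which 1 of the 3 values shown sits. The change from 3-chlorophenyl gives a 2.4-fold higher number from compound 1 to compound 3 (0.38 log units; beyond the scatter), which means that among these three aryl groups, 3-chlorophenyl gives the lowest number and so the strongest growth inhibition.

The names 3-chlorophenyl and 4-methoxyphenyl differ in both the substituent and its number on the phenyl ring, so the compounds shown cannot separate the effect of the group from that of its place. From the compounds shown here alone, it also remains open how a plain phenyl group or a longer alkyl chain on this nitrogen would compare.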